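This account rests on a few compounds, and the source may have more. Where it says the series, first, only, none or still open, it means among the compounds named here.

Working notes on the series. Compound 3 `C=C1C[C@]23C[C@@]1(O)CC[C@H]2c1ccc(O)c(C)c1[C@@H]3Cn1cc(-c2ccccc2)nn1` carries a hydroxy on an aromatic ring. In a functional assay on HL-60 cells (Homo sapiens) for cytotoxicity, read by MTT assay, with a stated time of 4 days (a higher number here means a weaker inhibitor, a lower number a stronger inhibitor), compound 3 gives only a limit, > 20000 nM. Compound 1 `C=C1C[C@]23C[C@@]1(O)CC[C@H]2c1ccc(OS(=O)(=O)c2ccc(C)cc2)c(C)c1[C@@H]3Cn1cc(-c2ccc(Br)cc2)nn1` instead carries the (4-methylphenyl)sulfonyl group on that oxygen and a bromo on an aromatic carbon; in this assay compound 1 likewise gives a limit, > 20000 nM. Compound 2 `C=C1C[C@]23C[C@@]1(O)CC[C@H]2c1ccc(OS(=O)(=O)c2ccc(C)cc2)c(C)c1[C@@H]3Cn1cc(-c2ccc(F)cc2)nn1` has fluoro in place of that bromo, and in this assay compound 2 also gives a limit, > 20000 nM. Among the compounds with values here, the step that the two limits leave unreadable from compound 1 to compound 2 is thus not readable, and every value in hand sits at the limit of > 20000 nM in this assay, at which 3 of the 3 values shown sit, so no measured step has a size that can be used.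

Compound 4 `C=C1C[C@]23C[C@@]1(O)CC[C@H]2c1ccc(OS(=O)(=O)c2ccc(C)cc2)c(C)c1[C@@H]3Cn1cc(-c2ccccc2)nn1` is the unmeasured member, differing from compound 3 by (4-methylphenyl)sulfonyl in place of hydrogen on an oxygen on an aromatic ring. Within the data shown here, no measured step bears directly on this change; the nearest comparison is that compounds 1 and 2, which carry the same sulfonyl ester, both stop at the limit. Compound 4 is therefore expected to remain at the limit as well, estimated at 30000 nM with a range from 10000 nM to 100000 nM. The implied step that the limit leaves unreadable from compound 3 to compound 4 is expected to be none beyond the scatter.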

Compound 4, half-maximal inhibitory concentration: > 20000 nM
Compound 4: a limit, no number (the forecaster's own chance of this, stated with the estimate: 85%); the middle value lies beyond the limit too.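

Compound 4 also stops at a limit, so its steps from compound 1, compound 2 and compound 3 cannot be read: the limit of > 20000 nM in this assay, at which 4 of the 4 values shown sit.

The compounds shown leave open what size any of these changes has in this assay, and which change to the shared core, if any, would give a value short of the limit.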